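Anilide change on a shared core: compound 2 to compound 3

The compounds below may be only part of what the source reports. "The series", "measured", "known", "first", "only" and "open" are said of these compounds alone.

Among the compounds with values here, compound 1 `Cc1cccc(NC(=O)c2ccc(/N=N\c3c[nH]c4ccccc34)cc2)c1C` is the only member with a number: in a functional assay on P388 cells (Mus musculus) for inhibition, read by MTT assay, with a stated time of 72 h (a lower number here means a stronger inhibitor, a higher number a weaker inhibitor), compound 1 gives 51600 nM. Compound 2 `Cc1ccccc1NC(=O)c1ccc(/N=N\c2c[nH]c3ccccc23)cc1` was reported in this assay as "not active" (no number reported), so no number stands for compound 2 and its place among the values cannot be fixed. Compound 3 `O=C(Nc1ccc(Cl)cc1)c1ccc(/N=N\c2c[nH]c3ccccc23)cc1` differs from compound 2 by 4-chlorophenyl in place of 2-methylphenyl on an amide-type nitrogen. Within the data shown here, no measured step covers this change. Compound 2 returned no number, and compound 3 is likewise expected to be weak, with a fair chance that this assay again reports no number. Compound 3 is estimated at 60000 nM, in the range 20000 nM to 200000 nM.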

Compound 3, half-maximal inhibitory concentration: 80000 nM
Estimate against measurement, compound 3: 1.3-fold (0.12 log units) below; the range from low to high includes it.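

In this assay the amide-type nitrogen now has a second numbered substituent: 4-chlorophenyl in place of 2,3-dimethylphenyl gives a 1.6-fold higher number from compound 1 to compound 3 (0.19 log units; within the scatter), so these two groups are not separated here. The step from compound 2 to compound 3 cannot be read: compound 2 was reported as not active, while compound 3 carries a number. No measurement on hand bears on a cause for these results.

Still open, as far as these compounds go, is whether a carboxylic acid or a dimethylamino group on this phenyl ring would shift the number beyond the scatter. From the compounds shown here alone, a longer chain on the nitrogen in place of the phenyl ring is equally open.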